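The compounds below may be only part of what the source reports. "The series", "measured", "known", "first", "only" and "open" are said of these compounds alone.

Three compounds built on one shared core differ only in the amine attached to a saturated chain carbon bound to a carbonyl carbon. Compound 1 `O=C(CNC1CCCCC1)N1N=C(c2cc3ccccc3oc2=O)CC1c1ccccc1` carries a cyclohexylamino group, compound 2 `O=C(CN1CCCC1)N1N=C(c2cc3ccccc3oc2=O)CC1c1ccccc1` a pyrrolidin-1-yl group, and compound 3 `CC1CCCCN1CC(=O)N1N=C(c2cc3ccccc3oc2=O)CC1c1ccccc1` a 2-methylpiperidin-1-yl group. In a functional assay on PC-3 cells (Homo sapiens) for cytotoxicity, read by MTT assay, with a stated time of 48 h (on this read-out higher numbers stand for weaker inhibition and lower numbers for stronger inhibition), compound 1 gives 48500 nM, compound 2 gives 50200 nM, and compound 3 gives 36300 nM. The steps between them are small: a 1.0-fold higher number from compound 1 to compound 2 (0.01 log units; within the scatter), a 1.3-fold lower number from compound 1 to compound 3 (0.13 log units; within the scatter), and a 1.4-fold lower number from compound 2 to compound 3 (0.14 log units; within the scatter). Compound 3 therefore holds the lowest of the three numbers, yet each of its steps to the other two lies within the scatter, so no real separation among the three is established.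

Compound 4 `CC1CCCN(CC(=O)N2N=C(c3cc4ccccc4oc3=O)CC2c2ccccc2)C1` is the next member. Relative to compound 3 the change is 3-methylpiperidin-1-yl in place of 2-methylpiperidin-1-yl on a saturated chain carbon bound to a carbonyl carbon. All three measured steps concern exchanges of the amine at this very position, and none of them left the scatter, which gives no ground for expecting a shift here either. The expectation for compound 4 is accordingly a number close to that of compound 3, with a 1.0-fold higher number from compound 3 to compound 4 (0.02 log units; within the scatter) in this assay, estimated at 38000 nM within a range from 19000 nM to 76000 nM.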

Compound 4, half-maximal inhibitory concentration: 28300 nM
Compound 4: the middle estimate sits 1.3-fold (0.13 log units) above what was measured; low and high end bracket the measured number.
By their numbers in this assay, from the lowest: compounds 4, 3, 1 and 2 (each within the scatter of the next).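

Among these compounds, compound 4 has the same atoms as compound 3, joined differently, so moving the methyl group gives the first isomer pair at this position, and in this assay it yields a 1.3-fold lower number from compound 3 to compound 4 (0.11 log units; within the scatter). Two further exchanges on a saturated chain carbon bound to a carbonyl carbon, a 1.8-fold lower number from compound 2 to compound 4 (0.25 log units; within the scatter) and a 1.7-fold lower number from compound 1 to compound 4 (0.23 log units; within the scatter), are the largest steps seen so far at this position, yet even these leave all four amines unseparated, and the position has so far shown no measurable response to ring size, to the exchange of cyclohexylamino for a ring-bound nitrogen, or to the placement of the methyl group. No outside evidence bears on these results.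

What the compounds shown leave open is whether any group at this position can move the number beyond the scatter, for example a morpholine or a piperazine, which would bring a second hetero atom into the ring, or a carboxylic acid on a longer chain. They also leave open whether the flat response holds when the amine stays fixed and the rest of the shared core is changed.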